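A few compounds are considered here, and "the series" means these few. Any claim that something is new, unique, unknown or untested is made for them only; others in the source may bear on it.

Compound 1 `N=C(NCc1ccccc1)[C@@H]1CCC(=O)N1Cc1ccc(F)cc1` gives 23.3% in a functional assay on SH-SY5Y cells (Homo sapiens) for cytotoxicity, read by MTT assay, with stated times of 8 h, 30 min and 12 h, tested at 0.5 uM; on this read-out lower numbers stand for a weaker effect and higher numbers for a stronger effect at the one concentration tested. Compound 2 `N=C(NCc1ccc(O)cc1)[C@@H]1CCC(=O)N1Cc1ccc(F)cc1` carries hydroxy in place of hydrogen on an aromatic carbon and in this assay compound 2 gives 42%, a step of a number 18.7 percentage points higher from compound 1 to compound 2 (beyond the scatter). Compound 3 `COc1ccc(CN2C(=O)CC[C@H]2C(=N)NCc2ccccc2)cc1` differs from compound 1 in its core by methoxy in place of fluoro on an aromatic carbon; in this assay compound 3 gives 21%, with a step of a number 2.3 percentage points lower from compound 1 to compound 3 (within the scatter). Compound 4 `COc1ccc(CN2C(=O)CC[C@H]2C(=N)NCc2ccc(O)cc2)cc1` is not yet measured; it arises from compound 3 by hydroxy in place of hydrogen on an aromatic carbon, the same change that turned compound 1 into compound 2, a change that occurs twice among these compounds. Compound 4 is expected to show a step of a number 18 percentage points higher from compound 3 to compound 4 (beyond the scatter) in this assay, because the earlier step of a number 18.7 percentage points higher from compound 1 to compound 2 (beyond the scatter) came from the same change and the two cores differ only by methoxy in place of fluoro on an aromatic carbon with a step of a number 2.3 percentage points lower from compound 1 to compound 3 (within the scatter). Compound 4 is therefore estimated at 39%, between 26% and 52%.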

Compound 4, a percentage reported as activity, at one concentration (the size of the read-out at that concentration, not a potency): 20.5%
Beside the measured number, compound 4's estimate is 18.5 percentage points above it, outside the stated range (below it).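

In this assay, hydroxy in place of hydrogen on an aromatic carbon gives a number 0.5 percentage points lower from compound 3 to compound 4 (within the scatter), so the effect seen on the core of compound 1 does not carry over to the core of compound 3: the same change on two cores in this assay, a number 18.7 percentage points higher (beyond the scatter) from compound 1 to compound 2 and a number 0.5 percentage points lower (within the scatter) from compound 3 to compound 4, 19.2 percentage points apart, beyond the scatter of two such steps Read the other way, methoxy in place of fluoro gives a number 21.5 percentage points lower from compound 2 to compound 4 (beyond the scatter), so that change also depends on the core that carries it: the same change on two cores in this assay, a number 2.3 percentage points lower (within the scatter) from compound 1 to compound 3 and a number 21.5 percentage points lower (beyond the scatter) from compound 2 to compound 4, 19.2 percentage points apart, beyond the scatter of two such steps The two changes are therefore not additive across these four compounds, but this does not show why, nor how either change would behave on any other core.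

The compounds shown leave open whether an amine or a carboxylic acid in place of the hydroxy would depend on the core in the same way. They also leave open whether a chloro group in place of the fluoro or methoxy would keep the hydroxy effect seen in compound 2.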